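This account rests on a few compounds, and the source may have more. Where it says the series, first, only, none or still open, it means among the compounds named here.

Measured compounds:
compound 1 `Cc1nc2cc(CCc3ccccc3)ccn2c1N`, 50%
compound 2 `Cc1nc2ccc(CCc3ccccc3)cn2c1N`, 52%
compound 3 `Cc1nc2c(OCc3ccccc3)cccn2c1/N=C/N(C)C`, 64%

Going by the values given here, in a functional assay on the whole organism with Rattus norvegicus as the target, at a dose of 40 mg/kg by the intraperitoneal route (on this read-out higher numbers stand for more inhibition at the one dose given (going by the name of the read-out) and lower numbers for less inhibition), compound 3 gives 64%, the highest of the numbers so far. The nearest value is that of compound 2, which lies lower by a margin beyond the scatter, and compound 1 lies lower still, also beyond the scatter. Compound 4 `COc1c(C)nc2c(OCc3ccccc3)cccn12` has not yet been measured. It differs from compound 3 in one place: a group of 2 heavy atoms (1 carbon, 1 oxygen; no ring) in place of a group of 5 heavy atoms (3 carbon, 2 nitrogen; no ring), on an aromatic carbon The group that leaves carries the one double bond outside aromatic rings; the methoxy that enters sits on an aromatic carbon of the five-membered aromatic ring with 2 nitrogen, next to the ring nitrogen and next to the ring atom that bears a methyl group. Among the compounds with values here, no pair of measured compounds covers this change, so its size cannot be read from a neighbouring step and has to be expected from compound 3 alone. The step from compound 3 to compound 4 is expected to run downward, by more than the scatter, at a number 24 percentage points lower from compound 3 to compound 4 (beyond the scatter). Compound 4 is therefore estimated at 40%, with a range from 18% to 60%, and the measurement will show where it falls.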

Compound 4, a percentage reported as inhibition, in the whole organism at one dose (the size of the read-out at that dose, not a potency): 49%
The estimate for compound 4 lay 9 percentage points below the measured number; the measured number falls inside the stated range.
By their numbers in this assay, from the lowest: compounds 4, 1 and 2 (each within the scatter of the next); then compound 3.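

In this assay, going by these compounds alone, methoxy in place of the larger open-chain group on the aromatic carbon of the five-membered ring gives a number 15 percentage points lower from compound 3 to compound 4 (beyond the scatter) and is the first reading of any change at this position. The carbon accepts a group without nitrogen and without a double bond outside aromatic rings, and inhibition does not vanish: compound 4 still gives 49% at the one dose, though the larger group of compound 3 reads higher. The two groups match in their counts of hydrogen-bond donors and acceptors, so those counts do not track this step, and no measurement on hand bears on what lies behind it.

Within the data shown here, the single step cannot separate the effects of the number of heavy atoms, the double bond and the nitrogens, so which of these goes with the higher reading of compound 3 stays open. Also open, from the compounds shown here alone, is what an amine, a hydroxyl or a longer alkoxy chain would give on this same carbon with the rest of compound 3 kept, and whether the order of these two compounds would hold at another dose.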